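The compounds below may be only part of what the source reports. "The series", "measured", "known", "first", "only" and "open" are said of these compounds alone.

Of the compounds shown here, two sharing one core have been measured so far in a functional assay on RT-112 cells (Homo sapiens) for antiproliferative activity, read by MTT assay, with a stated time of 72 h; a lower number here means a stronger inhibitor of growth, a higher number a weaker inhibitor of growth. Compound 1 `COc1cc(Nc2ncnc3c(NC(=O)Nc4cccc(Oc5ccccc5)c4)cccc23)cc(OC)c1` gives 14000 nM, while compound 2 `COc1cc(Nc2ncnc3c(NC(=O)Nc4ccc(C)cc4C)cccc23)cc(OC)c1` gives 1290 nM. Compound 2 thus holds the lower of the two numbers, with a gap beyond the usual scatter. Compound 3 `COc1cc(Nc2ncnc3c(NC(=O)Nc4ccccc4Cl)cccc23)cc(OC)c1` has not yet been measured in this assay. It differs from compound 2 in one place, on an amide-type nitrogen, where 2-chlorophenyl stands in place of 2,4-dimethylphenyl: 2-chlorophenyl in place of 2,4-dimethylphenyl on an amide-type nitrogen. Going by the values given here, no measured pair shows a change of this kind, so the expectation starts from compound 2 at 1290 nM and from the small size of the exchange. The expected step of a 1.4-fold higher number from compound 2 to compound 3 (0.14 log units; within the scatter) leans slightly towards a higher number and is estimated to stay within the scatter. For compound 3 the expected value is 1800 nM, with an estimated range from 600 nM to 6000 nM.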

Compound 3, concentration for 50% growth inhibition: 356 nM
Estimate against measurement, compound 3: 5.1-fold (0.70 log units) above, outside the stated range (below it).
By their numbers in this assay, from the lowest: compound 3; then compound 2; then compound 1.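

The exchange of 2,4-dimethylphenyl for 2-chlorophenyl on an amide-type nitrogen gives a 3.6-fold lower number from compound 2 to compound 3 (0.56 log units; beyond the scatter) in this assay, so this position responds beyond the scatter to a small exchange, with 8 heavy atoms leaving and 7 entering and no hydrogen-bond donors or acceptors on either group. This single step does not separate the entry of chlorine from the loss of the methyl carbons. The data shown offer no measurement that explains the step.

Going by these compounds, it remains open whether the lower number persists with other groups on this nitrogen, such as 2-bromophenyl, 2-methylphenyl or a phenyl ring bearing an amine. On these data alone, it is also open whether a step of this size would recur with another part of the shared structure changed.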